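A few compounds are considered here, and "the series" means these few. Any claim that something is new, unique, unknown or untested is made for them only; others in the source may bear on it.

Of the compounds shown here, three sharing one core have been measured in a functional assay on A549 cells (Homo sapiens) for cytotoxicity, read by MTT assay, with a stated time of 72 h; on this read-out higher numbers stand for weaker inhibition and lower numbers for stronger inhibition. Compound 1 `CN(C)CCn1cnnc1-c1cc(Oc2ccc(NC(=O)N/N=C/c3c[nH]c4ccccc34)cc2F)ccn1` gives 820 nM. Compound 2 `Cc1cc(/C=N/NC(=O)Nc2ccc(Oc3ccnc(-c4nncn4CCN(C)C)c3)c(F)c2)cc(C)c1O` gives 1640 nM, and the step of a 2.0-fold higher number from compound 1 to compound 2 (0.30 log units; within the scatter) stays within the scatter. Compound 3 `COc1cc(/C=N/NC(=O)Nc2ccc(Oc3ccnc(-c4nncn4CCN(C)C)c3)c(F)c2)ccc1O` reaches only a limit in this assay, > 100000 nM, so its true number is not known. Compound 3 thus stands at the weak end of the three, as the step of an at least 120-fold higher number from compound 1 to compound 3 (2.08 log units; beyond the scatter) and the step of an at least 60-fold higher number from compound 2 to compound 3 (1.78 log units; beyond the scatter) show; both are large, and the limit of > 100000 nM in this assay, at which 1 of the 3 values shown sits, marks where compound 3 sits.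

Compound 4 `CN(C)CCn1cnnc1-c1cc(Oc2ccc(NC(=O)N/N=C/c3ccc(Cl)cc3Cl)cc2F)ccn1` has not been measured. It differs from compound 3 in one place: 2,4-dichlorophenyl in place of 4-hydroxy-3-methoxyphenyl on a carbon with a double bond to nitrogen. Among the compounds with values here, no measured step involves the group that enters, so the expectation rests on the two large steps toward compound 3 and on the fact that compound 1 and compound 2 both give numbers rather than limits. Within the data shown here, the group that leaves is present only in compound 3, the sole compound at the limit, so its removal is expected to bring compound 4 back toward the numbers of compound 1 and compound 2, though how far is uncertain. The step from compound 3 is expected to be an at least 40-fold lower number from compound 3 to compound 4 (1.60 log units; beyond the scatter), a move toward lower numbers. For compound 4 the expected value in this assay is 2500 nM, with a range from 500 nM to 30000 nM.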

Compound 4, half-maximal inhibitory concentration: 810 nM
For compound 4 the middle estimate is 3.1-fold (0.49 log units) above the measured one; measured number inside the range.
By their numbers in this assay, from the lowest: compounds 4, 1 and 2 (each within the scatter of the next, the first and the last beyond it). At a limit, above all of these: compound 3.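

Replacing 4-hydroxy-3-methoxyphenyl with 2,4-dichlorophenyl on the carbon with a double bond to nitrogen gives an at least 120-fold lower number from compound 3 to compound 4 (2.09 log units; beyond the scatter), so this position accepts a ring with 0 hydrogen-bond donors and 0 hydrogen-bond acceptors and still gives a measurable number. The other comparisons place this new group alongside the earlier ones: the change from 1H-indol-3-yl gives a 1.0-fold lower number from compound 1 to compound 4 (0.01 log units; within the scatter), while the change from 4-hydroxy-3,5-dimethylphenyl gives a 2.0-fold lower number from compound 2 to compound 4 (0.31 log units; beyond the scatter), a modest step. With a third, quite different group giving a number, compound 3 remains the only compound at a limit of the assay: the limit of > 100000 nM in this assay, at which 1 of the 4 values shown sits.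

As far as these compounds go, whether both chlorines are needed remains open, as does how 2-chlorophenyl or 4-chlorophenyl alone, or a phenyl ring carrying an amine or a carboxylic acid, would behave in this assay. These compounds also do not explain why compound 3 reaches a limit while compound 2, which also carries a hydroxy group on its ring, gives a number.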